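The source may hold more compounds than are shown below. What is called first, only, known or untested is meant among the compounds shown, and "the series" means these compounds.

Working notes on the series.

Compound 1 `CS(=O)(=O)Oc1c(C(=O)NCc2ccc(F)cc2)nc(Br)c2cccnc12` was measured in a functional assay on MDA-MB-435 cells (Homo sapiens) for cytotoxicity, read by MTT assay, with a stated time of 72 h; on this read-out lower numbers stand for stronger inhibition and higher numbers for weaker inhibition. In this assay compound 1 gives only a limit, > 20000 nM. Compound 2 `C[C@H](NC(=O)c1nc(Br)c2cccnc2c1N[C@H]1CC[C@H](N)CC1)c1ccc(F)cc1` likewise reaches only a limit in this assay, > 10000 nM. Compound 3 `C[C@@H](CO)Nc1nc(C(=O)NCc2ccc(F)cc2)c(O)c2ncccc12` also sits at a limit in this assay, > 20000 nM. Within the data shown here, compound 1 therefore cannot be ranked against the other two: every value shown is a limit, as recorded in the limit of > 20000 nM in this assay, at which 2 of the 3 values shown sit, and (the limit of > 10000 nM in this assay, at which 1 of the 3 values shown sits), and no step between measured compounds can be computed.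

Compound 4 `CNCCCNc1c(C(=O)NCc2ccc(F)cc2)nc(Br)c2cccnc12` is the next analogue to be tested. It differs from compound 1 by (3-(methylamino)propyl)amino in place of (methylsulfonyl)oxy on an aromatic carbon. Among the measured compounds shown here, with nothing but limits on hand, the numbers give no direction for this change; the most that can be said is that the three measured members all failed to show measurable cytotoxicity. The step from compound 1 to compound 4 is expected to be an at least 1.3-fold lower number from compound 1 to compound 4 (0.12 log units; that floor lies within the scatter), nothing beyond the scatter. Compound 4 is estimated to give about 15000 nM in this assay, within 4000 nM to 40000 nM.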

Compound 4, half-maximal inhibitory concentration: 11000 nM
Estimate against measurement, compound 4: 1.4-fold (0.13 log units) above, within the range that was stated.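

Among these compounds, at the aromatic carbon para to a bromo group, (3-(methylamino)propyl)amino in place of (methylsulfonyl)oxy gives the first reading in this assay that is a number and not a limit. The change reads as an at least 1.8-fold lower number from compound 1 to compound 4 (0.25 log units; that floor lies within the scatter). Only a floor can be given for this step, and its true size stays unknown because the value of compound 1 is itself a limit: the limit of > 20000 nM in this assay, at which 2 of the 4 values shown sit.

The compounds shown do not separate the contribution of the amino link on the aromatic carbon from that of the methylamino end of the chain. A shorter chain, a longer chain, a primary amine or a carboxylic acid at the chain end would be needed to tell whether the reading at this position moves beyond the scatter.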